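The source may hold more compounds than are shown below. What is called first, only, known or untested is meant among the compounds shown, and "the series" means these compounds.

Compound 1 `c1ccc2c(c1)CN[C@@H](CN(CCCCNCc1ccncc1)[C@H]1CCCc3cccnc31)C2` was measured in a functional assay on cells for agonist activity at C-X-C chemokine receptor type 4 (Homo sapiens), read by fluorescence and calcium flux, with a stated time of 90 s (a lower number here means that less compound is needed, a higher number that more compound is needed for the effect), where compound 1 gives only a limit, > 30000 nM. Compound 2 `c1ccc2c(c1)CN[C@@H](CN(CCCCNCC1CCSCC1)[C@H]1CCCc3cccnc31)C2` likewise gives only a limit in this assay, > 30000 nM. Compound 3 `O=S1(=O)CCC(NCCCCN(C[C@H]2Cc3ccccc3CN2)[C@H]2CCCc3cccnc32)CC1` also gives only a limit in this assay, > 30000 nM. The steps a step that the two limits leave unreadable from compound 1 to compound 2, a step that the two limits leave unreadable from compound 1 to compound 3 and a step that the two limits leave unreadable from compound 2 to compound 3 cannot be read, because of the limit of > 30000 nM in this assay, at which 3 of the 3 values shown sit. Compound 4 `CC(C)(CCN(C[C@H]1Cc2ccccc2CN1)[C@H]1CCCc2cccnc21)CNCC1CCOCC1` differs from compound 3 by a group of 12 heavy atoms (10 carbon, 1 nitrogen, 1 oxygen; one six-membered non-aromatic ring with 1 hetero atom) in place of a group of 11 heavy atoms (7 carbon, 1 nitrogen, 2 oxygen, 1 sulfur; one six-membered non-aromatic ring with 1 hetero atom), on a saturated chain carbon, two bonds along the chain from an amine nitrogen. Within the data shown here, none of the measured steps bear readably on this change, and compound 3 stands at the limit. Compound 4 is therefore expected to remain near that limit in this assay, with a step of a number no higher from compound 3 to compound 4 (the limit leaves the size open) estimated as none beyond the scatter. The estimate for compound 4 in this assay is 30000 nM, with a range from 8000 nM to 100000 nM.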

Compound 4, half-maximal effective concentration: > 30000 nM
Compound 4 ended at the assay's limit; the forecaster's own chance of this, stated with the estimate: 85%; the middle value sits exactly at the limit.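

No new step can be read between compound 4 and compound 1, compound 2 or compound 3 in this assay, because all four stand at one limit: the limit of > 30000 nM in this assay, at which 4 of the 4 values shown sit. The compounds shown leave open how much of each, if any, would give the effect.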